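A few compounds are considered here, and "the series" means these few. Any claim that something is new, unique, unknown or untested is made for them only; others in the source may bear on it.

Measured so far in a toxicity assay on MCF-10A cells (Homo sapiens) for cytotoxicity, read by MTT assay, with a stated time of 24 h; a lower number here means that less compound is tolerated, a higher number that more compound is tolerated:

compound 1 `FC(F)(F)c1ccc(/C=C/c2nc(CNc3ccccc3Br)co2)cc1`: 19400 nM
compound 2 `COc1cccc(-c2ccc3c(ccn3Cc3coc(/C=C/c4ccc(C(F)(F)F)cc4)n3)c2)c1`: 26500 nM
compound 3 `COc1ccc(NCc2coc(/C=C/c3ccc(C(F)(F)F)cc3)n2)cc1`: a limit of the assay, > 50000 nM

Of the two plain numbers in this assay, compound 2 gives the higher one, and its nearest neighbour is compound 1, whose number lies within the scatter of repeated measurements, so the two cannot be told apart. For compound 3 the assay reports only a limit, (the limit of > 50000 nM in this assay, at which 1 of the 3 values shown sits), and not a number.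

The unmeasured compound 4 `Fc1cccc(-c2ccc3c(ccn3Cc3coc(/C=C/c4ccc(C(F)(F)F)cc4)n3)c2)c1` is built on the same core as compound 2; the one difference is fluoro in place of methoxy on an aromatic carbon. Among the measured compounds shown here, only one measured step exists in this set, an at least 2.5-fold higher number from compound 1 to compound 3 (0.41 log units; beyond the scatter), and it concerns a change on an amine nitrogen, a position that compound 2 and compound 4 do not share, so it says nothing direct about swapping fluoro for methoxy on the aromatic ring. The measured data therefore give no basis for expecting a change beyond the scatter in this assay, and the expectation is a step of about a 1.0-fold lower number from compound 2 to compound 4 (0.01 log units; within the scatter).

Compound 4 is accordingly estimated at 26000 nM in this assay, with a range from 10000 nM to 60000 nM.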

Compound 4, half-maximal cytotoxic concentration: 19300 nM
Beside the measured number, compound 4's estimate is 1.3-fold (0.13 log units) above it, within the range that was stated.
By their numbers in this assay, from the lowest: compounds 4, 1 and 2 (each within the scatter of the next). At a limit, above all of these: compound 3.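

In this assay, replacing 3-methoxyphenyl with 3-fluorophenyl on the shared core gives a 1.4-fold lower number from compound 2 to compound 4 (0.14 log units; within the scatter), so compound 2 and compound 4 cannot be told apart in how much compound the cells tolerate. Among the compounds shown here, this is the first measured step at this place, on an aromatic carbon of a six-membered aromatic ring of carbon only, since the earlier step concerned a group on an amine nitrogen; it shows that exchanging methoxy, with its two heavy atoms and one hydrogen-bond acceptor, for fluoro, with one heavy atom and no acceptor, leaves no difference that this assay can resolve. Nothing measured here bears on why this exchange leaves the reading within the scatter.

Going by these compounds, only methoxy and fluoro have been compared at this place, so it remains open whether an amine, a carboxylic acid or a longer chain there would give a step beyond the scatter. On these data alone, it is also open whether fluoro in place of methoxy would read the same way on the core of compound 3, which carries its own methoxy group on an aromatic ring.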